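Spiro series, aryl swap on the triazole, antiproliferation notes

The source may hold more compounds than are shown below. What is called first, only, known or untested is meant among the compounds shown, and "the series" means these compounds.

Measured compounds:
compound 1 `N#CC1=C(N)Oc2c(c3nc4ccccc4nc3c3ccccc23)C12C(=O)N(Cc1cnnn1-c1ccc([N+](=O)[O-])cc1)c1ccccc12` — in a functional assay on HepG2 cells (Homo sapiens) for antiproliferative activity, read by MTT assay, with a stated time of 48 h (a higher number here means a weaker inhibitor, a lower number a stronger inhibitor), compound 1 gives > 50000 nM, which is a limit of the assay and not a number.
compound 2 `N#CC1=C(N)Oc2c(N)cc3nc4ccccc4nc3c2C12C(=O)N(Cc1cnnn1-c1ccc(Cl)cc1)c1ccccc12` — in this assay compound 2 gives > 50000 nM, again a limit of the assay.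

Compound 2 therefore stands at the upper edge of what this assay reports: no number, only the limit, and the same holds for compound 1, so the two values cannot be set in order against each other (the limit of > 50000 nM in this assay, at which 2 of the 2 values shown sit).

Compound 3 `Cc1ccc(-n2nncc2CN2C(=O)C3(C(C#N)=C(N)Oc4c(N)cc5nc6ccccc6nc5c43)c3ccccc32)cc1C` is not yet measured. It differs from compound 2 in one place: 3,4-dimethylphenyl in place of 4-chlorophenyl on an aromatic nitrogen. The shared core, the spiro junction, the nitrile and the amine on the aromatic ring are unchanged.

Going by the values given here, no measured pair is separated by a single change, so there is no measured step to lean on for the size of this one. With compound 2 sitting at the limit, the expectation for compound 3 is that the step that the limit leaves unreadable from compound 2 to compound 3 stays within the scatter, in no clear direction. Compound 3 is estimated at 60000 nM in this assay, within 20000 nM to 200000 nM, most likely reported again as a limit.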

Compound 3, half-maximal inhibitory concentration: > 50000 nM
Compound 3: a limit, no number; the forecaster's own chance of this, stated with the estimate: 80%; the middle value is on the limit's open side.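

In this assay compound 3 gives > 50000 nM, again a limit of the assay and not a number. No step can be read from compound 2 to compound 3, as both values are limits: the limit of > 50000 nM in this assay, at which 3 of the 3 values shown sit. The compounds shown leave open how the aryl group on the aromatic nitrogen affects the read-out in this assay, since none gives a number.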